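The compounds below may be only part of what the source reports. "The series", "measured", "known", "first", "only" and "open" are said of these compounds alone.

Compound 1 `CCOC(=O)C(Cn1ccnc1)NC(=O)c1c(C)nn(-c2ccccc2)c1Cl` gives 600 nM in an assay on HL-60 cells for inhibition of cytochrome P450 26A1 (Homo sapiens), read by HPLC, using microsomes and NADPH, with a stated time of 30 min; a higher number here means a weaker inhibitor, a lower number a stronger inhibitor. Compound 2 `Cc1nn(-c2ccccc2)c(Cl)c1C(=O)NC(Cn1ccnc1)C(=O)OC(C)C` carries methyl in place of hydrogen on a saturated chain carbon bound to an oxygen next to a carbonyl group and a saturated chain carbon, and in this assay compound 2 gives 460 nM, a step of a 1.3-fold lower number from compound 1 to compound 2 (0.12 log units; within the scatter). Compound 3 `CCOC(=O)C(Cn1ccnc1)NC(=O)c1nc2ccccc2s1` rests on a different core; the difference between the two cores is not broken down here. In this assay compound 3 gives 740 nM. Compound 4 `CC(C)OC(=O)C(Cn1ccnc1)NC(=O)c1nc2ccccc2s1` is built from compound 3 by the same change, (methyl in place of hydrogen on a saturated chain carbon bound to an oxygen next to a carbonyl group and a saturated chain carbon), and has not yet been measured in this assay. Because the same change gave a 1.3-fold lower number from compound 1 to compound 2 (0.12 log units; within the scatter), the step from compound 3 to compound 4 is expected to be about as small, a 1.3-fold lower number from compound 3 to compound 4 (0.11 log units; within the scatter). Compound 4 is therefore estimated to give 570 nM, with the likely range running from 300 nM to 1100 nM.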

Compound 4, half-maximal inhibitory concentration: 630 nM
Compound 4: middle estimate off by 1.1-fold (0.04 log units), on the low side, and the stated range covers the measured number.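

In this assay the exchange of ethoxycarbonyl for isopropoxycarbonyl gives a 1.2-fold lower number from compound 3 to compound 4 (0.07 log units; within the scatter) and, set beside the earlier step, it reads the same on both cores: the same change on two cores in this assay, a 1.3-fold lower number (0.12 log units; within the scatter) from compound 1 to compound 2 and a 1.2-fold lower number (0.07 log units; within the scatter) from compound 3 to compound 4, 1.1-fold (0.05 log units) apart, within the scatter of two such steps. Both steps lie within the scatter, so the change from ethyl to isopropyl carries across these two cores without a clear effect on either. This does not show that the change would behave alike on a third core, nor that the ester is unimportant in general.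

The compounds shown leave open how a longer chain such as a butyl ester, or a carboxylic acid in place of the ester, would read. They also leave open whether an amide in place of the ester would fit the same picture on either core.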